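Replacing halogens with methyls on the aryl of compound 3

The source may report more compounds than this note shows. Statements on the series, on what has been measured and on what is new or still open speak of the compounds shown alone.

compound 1 `CCc1ccccc1-n1ncc(C(=O)Nc2ccc3ccccc3n2)c1C`: 9700 nM
compound 2 `CC(C)c1c(C(=O)Nc2ccc3ccccc3n2)cnn1-c1ccccc1`: 17300 nM
compound 3 `Cc1c(C(=O)Nc2ccc3ccccc3n2)cnn1-c1c(F)cccc1Br`: 3900 nM

In a functional assay on SW480 cells (Homo sapiens) for inhibition (on this read-out lower numbers stand for stronger inhibition of growth and higher numbers for weaker inhibition of growth), compound 3 stands lowest of the three numbers; compound 1 is nearest, compound 2 furthest, both beyond the scatter. Compound 4 `Cc1cccc(C)c1-n1ncc(C(=O)Nc2ccc3ccccc3n2)c1C` differs from compound 3 in one place: 2,6-dimethylphenyl in place of 2-bromo-6-fluorophenyl on an aromatic nitrogen. Among the measured compounds shown here, the only measured step at this position is a 2.5-fold lower number from compound 1 to compound 3 (0.40 log units; beyond the scatter), which shows that the group on the aromatic nitrogen matters at a modest scale. Compound 4 keeps two groups flanking the attachment, like compound 3, but loses the halogens, so a modest upward step is expected, roughly half-way back toward compound 1, estimated as a 1.5-fold higher number from compound 3 to compound 4 (0.19 log units; within the scatter). Compound 4 is therefore expected to give about 6000 nM in this assay, with a range from 2500 nM to 15000 nM.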

Compound 4, concentration for 50% growth inhibition: 7200 nM
Beside the measured number, compound 4's estimate is 1.2-fold (0.08 log units) below it, within the range that was stated.
By their numbers in this assay, from the lowest: compounds 3, 4, 1 and 2 (each within the scatter of the next, the first and the last beyond it).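

At this position in this assay, putting methyls in place of both halogens gives a 1.8-fold higher number from compound 3 to compound 4 (0.27 log units; within the scatter), and 2,6-dimethylphenyl in place of 2-ethylphenyl gives a 1.3-fold lower number from compound 1 to compound 4 (0.13 log units; within the scatter). Compound 4 therefore cannot be told apart from either compound, even though a 2.5-fold lower number from compound 1 to compound 3 (0.40 log units; beyond the scatter) separates those two, so it does not show whether that earlier gap belongs to the halogens or to the second group on the phenyl ring. Nothing available explains these numbers. Still open, going by these compounds, is how this phenyl ring would read with a methoxy group or an amine in place of the methyls.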